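Swapping a Benzyl Group for a Cyclohexyl Group

The source may report more compounds than this note shows. Statements on the series, on what has been measured and on what is new or still open speak of the compounds shown alone.

- compound 1 `O=C(NCCNS(=O)(=O)c1ccc(-c2ccccc2O[C@H]2CC[C@H](O)CC2)s1)Nc1ccc([N+](=O)[O-])cc1`: 4100 nM
- compound 2 `O=[N+]([O-])c1ccc(NC(=S)NCCNS(=O)(=O)c2ccc(-c3ccccc3O[C@H]3CC[C@@H](O)CC3)s2)cc1`: 9400 nM
- compound 3 `O=[N+]([O-])c1ccc(NC(=S)NCCNS(=O)(=O)c2ccc(-c3ccccc3OCc3cccc(O)c3)s2)cc1`: 10100 nM

In a functional assay on RS4-11 cells (Homo sapiens) for inhibition, read by CCK-8 assay, with a stated time of 48 h (on this read-out higher numbers stand for weaker inhibition and lower numbers for stronger inhibition), compound 3 gives 10100 nM. That sits within the scatter of compound 2 at 9400 nM, while compound 1 shows a lower number, 4100 nM, a gap beyond the scatter. A lower number here means stronger inhibition.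

The next compound to consider is compound 4 `O=[N+]([O-])c1ccc(NC(=S)NCCNS(=O)(=O)c2ccc(-c3ccccc3O[C@H]3CC[C@H](O)CC3)s2)cc1`. It is reached from compound 3 by one change: 4-hydroxycyclohexyl in place of 3-hydroxybenzyl on an oxygen on an aromatic ring. In plain terms, 4-hydroxycyclohexyl takes the place of 3-hydroxybenzyl on an oxygen on an aromatic ring.

Among the measured compounds shown here, the one measured step that bears on this is the same swap in the opposite direction, a 1.1-fold higher number from compound 2 to compound 3 (0.03 log units; within the scatter). Compound 2 holds the 4-hydroxycyclohexyl group with the other spatial arrangement at its ring, so this comparison is close but not exact. For the measured compounds named here, compound 1 also carries a 4-hydroxycyclohexyl group and gives 4100 nM, but no measured step links it to compound 4, so it only stretches the expected range downward.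

No shift beyond the scatter is therefore expected in this assay. The expected change is a 1.3-fold lower number from compound 3 to compound 4 (0.10 log units; within the scatter). For compound 4 the estimated value is 8000 nM, with an expected range from 4000 nM to 16000 nM.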

Compound 4, half-maximal inhibitory concentration: 1500 nM
The estimate for compound 4 lay 5.3-fold (0.73 log units) above the measured number; measured number below the stated range.
By their numbers in this assay, from the lowest: compound 4; then compound 1; then compounds 2 and 3 (each within the scatter of the next).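

In this assay, replacing 3-hydroxybenzyl with 4-hydroxycyclohexyl on an oxygen on an aromatic ring can matter a great deal, with a 6.7-fold lower number from compound 3 to compound 4 (0.83 log units; beyond the scatter). The outcome depends on the spatial arrangement of the 4-hydroxycyclohexyl ring, which the earlier compounds could not show: with a 6.3-fold lower number from compound 2 to compound 4 (0.80 log units; beyond the scatter), this arrangement alone can account for the gap, because of this structural relationship: the fact that compounds 2 and 4 differ only in the configuration as drawn. The arrangement is not the only thing that counts, since a change on an amine nitrogen, where a group holding sulfur takes the place of one holding an extra oxygen, comes with a 2.7-fold lower number from compound 1 to compound 4 (0.44 log units; beyond the scatter) between two compounds that share the same ring arrangement.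

The compounds shown leave open whether the arrangement of the ring matters as much when the oxygen-holding group sits on that amine nitrogen, as compound 1 has no partner of the opposite arrangement here. They also leave open whether the hydroxyl on the ring is needed, as none of them carries an amine or a carboxylic acid in its place.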